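The compounds below may be only part of what the source reports. "The series", "measured", "known", "first", "only" and "open" are said of these compounds alone.

Measured so far:
compound 1 `O=C(NCCCCc1ccccc1)Oc1cccc(-c2ccccc2)c1` — 35.9%
compound 2 `O=C(NC1CCCC1)Oc1cccc(-c2ccccc2)c1` — 34.4%
compound 3 `O=C(NC1CCC1)Oc1cccc(-c2ccccc2)c1` — 22.6%

In a physicochemical assay, read by HPLC, in phosphate buffer, at pH 7.0 (a lower number here means that less of the compound is left, a higher number that more of the compound is left), compound 1 stands highest of the three numbers; compound 2 lies within the scatter of it, while compound 3 lies beyond the scatter below it. Compound 4 `CCCCNC(=O)Oc1cccc(-c2ccccc2)c1` differs from compound 1 in one place: hydrogen in place of phenyl on a saturated chain carbon, four bonds along the chain from an amide-type nitrogen. Among the measured compounds shown here, the single measured step, a number 11.8 percentage points lower from compound 2 to compound 3 (beyond the scatter), swaps one ring for another on the amide-type nitrogen and says nothing about shortening a chain, so no measured step bears directly on this change. With that, a step of only modest size in either direction is expected, a number 5.9 percentage points lower from compound 1 to compound 4 (within the scatter). Compound 4 is therefore estimated at 30%, with a range from 15% to 45%.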

Compound 4, percent of the compound remaining: 46.7%
Compound 4: middle estimate off by 16.7 percentage points, on the low side; the measured number lies above the stated range.
By their numbers in this assay, from the lowest: compound 3; then compounds 2 and 1 (each within the scatter of the next); then compound 4.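

Taking the phenyl off the saturated chain carbon, four bonds along the chain from the amide-type nitrogen, gives a number 10.8 percentage points higher from compound 1 to compound 4 (beyond the scatter) in this assay and so shows that more of the compound is left without this phenyl. A butyl chain on that nitrogen also stands above both rings, with a number 12.3 percentage points higher from compound 2 to compound 4 (beyond the scatter) and a number 24.1 percentage points higher from compound 3 to compound 4 (beyond the scatter) as the steps. Nothing available explains these steps. Still open, on these data alone, is where a shorter ethyl chain or a longer hexyl chain would fall, and what a hydroxyl or an amine on the butyl chain would do.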